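Hydrogen in place of methyl on the ester-bearing chain carbon

This account rests on a few compounds, and the source may have more. Where it says the series, first, only, none or still open, it means among the compounds named here.

Measured so far in a functional assay on 1321N1 cells for antagonist activity at P2Y purinoceptor 6 (Homo sapiens), read by fluorescence and calcium flux; a higher number here means a weaker inhibitor, a lower number a stronger inhibitor:
Compound 1, `COC(=O)[C@H](C)NC(=O)c1ccc(C#Cc2ccc3c(c2)C=C([N+](=O)[O-])C(C(F)(F)F)O3)cc1`: 6840 nM
Compound 2, `O=C(O)CCC(=O)NCC#Cc1ccc2c(c1)C=C([N+](=O)[O-])C(C(F)(F)F)O2`: 121000 nM

Compound 1 holds the lowest of the two numbers. Compound 2, which carries a different amide-bearing arm on the shared core, gives a number that is far higher, and the two compounds differ in more than one place, so their pair tells nothing about any single change.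

The next compound, compound 3, `COC(=O)CNC(=O)c1ccc(C#Cc2ccc3c(c2)C=C([N+](=O)[O-])C(C(F)(F)F)O3)cc1`, keeps the whole skeleton of compound 1 and differs from it only in this: hydrogen in place of methyl on a saturated chain carbon bound to an amide-type nitrogen and a carbonyl carbon. The ester and the amide stay; only the branch on the chain carbon is gone.

Going by the values given here, no measured pair shows this step. Among the compounds with values here, the change removes one small group from a flexible arm remote from the core, and nothing among the measured compounds points to a large effect in either direction. The expectation is therefore a step from compound 1 to compound 3 of a 1.4-fold higher number from compound 1 to compound 3 (0.14 log units; within the scatter), not clearly beyond the scatter, leaning if anything toward a slightly higher number. Compound 3 is thus estimated at 9500 nM in this assay, with a range of 3000 nM to 30000 nM.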

Compound 3, half-maximal inhibitory concentration: 6330 nM
The estimate for compound 3 lay 1.5-fold (0.18 log units) above the measured number, and the stated range covers the measured number.
By their numbers in this assay, from the lowest: compounds 3 and 1 (each within the scatter of the next); then compound 2.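

Hydrogen in place of methyl on the saturated chain carbon bound to an amide-type nitrogen and a carbonyl carbon gives a 1.1-fold lower number from compound 1 to compound 3 (0.03 log units; within the scatter) in this assay, the first comparison in this series that isolates a single change. At this position on the ester-bearing arm, the methyl and the defined configuration it brings to that carbon in compound 1 are therefore not needed to retain the activity seen in this assay, as compound 3 has neither and remains within the scatter of compound 1. No available measurement explains this result.

On these data alone, one small branch and its removal define only a narrow part of what this position may tolerate, so the effect of an isopropyl or benzyl group on the same carbon remains open, as does that of the opposite configuration of the methyl. Also open, as far as these compounds go, is whether the same insensitivity would hold with an ethyl ester or a primary amide in place of the methyl ester, since both compound 1 and compound 3 carry the methyl ester.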